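Removing a Ring Methyl from Two Related Anilino-Thiophene Cores

The compounds below may be only part of what the source reports. "The series", "measured", "known", "first", "only" and "open" are said of these compounds alone.

Compound 1 `COC(=O)c1sc2cc(C)ccc2c1Nc1cc(OC)c(OC)c(OC)c1`: 20.5 nM
Compound 2 `COC(=O)c1sc2nc(C)ccc2c1Nc1cc(OC)c(OC)c(OC)c1`: 0.4 nM
Compound 3 `COC(=O)c1sc2ncccc2c1Nc1cc(OC)c(OC)c(OC)c1`: 2920 nM

Three compounds were measured in a functional assay on HL-60 cells (Homo sapiens) for cytotoxicity, read by MTT assay, with a stated time of 72 h; a higher number here means a weaker inhibitor, a lower number a stronger inhibitor. Compound 2 gives 0.4 nM, compound 3 gives 2920 nM, and compound 1 gives 20.5 nM. Compound 3 differs from compound 2 by hydrogen in place of methyl on an aromatic carbon, and this step was a 7300-fold higher number from compound 2 to compound 3 (3.86 log units; beyond the scatter). The difference between the cores of compound 1 and compound 2 is not broken down here.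

Compound 4 `COC(=O)c1sc2ccccc2c1Nc1cc(OC)c(OC)c(OC)c1` has not been measured. It differs from compound 1 by hydrogen in place of methyl on an aromatic carbon. This is the same kind of change as that from compound 2 to compound 3, but not the same: there the ring is a six-membered aromatic ring with 1 nitrogen and the position is next to the ring nitrogen, whereas here the ring is of carbon only. Because the earlier step was a 7300-fold higher number from compound 2 to compound 3 (3.86 log units; beyond the scatter), a weakening is expected for compound 4, estimated as a 20-fold higher number from compound 1 to compound 4 (1.29 log units; beyond the scatter), with wide uncertainty since the surroundings of the change differ. Compound 4 is estimated at 400 nM, between 40 nM and 4000 nM.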

Compound 4, half-maximal inhibitory concentration: 1540 nM
Compound 4: middle estimate off by 3.9-fold (0.59 log units), on the low side; low and high end bracket the measured number.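

In this assay, removing the methyl from the aromatic carbon also weakened the carbon-only core, giving a 75-fold higher number from compound 1 to compound 4 (1.88 log units; beyond the scatter). The direction of the change therefore carried from one core to the other in these two cases, but its size did not: the same change on two cores in this assay, a 7300-fold higher number (3.86 log units; beyond the scatter) from compound 2 to compound 3 and a 75-fold higher number (1.88 log units; beyond the scatter) from compound 1 to compound 4, 97-fold (1.99 log units) apart, beyond the scatter of two such steps. These two steps show that the change costs much on both cores and that the cost depends on the core, but they do not show why the two differ, and they give no rule for any further core.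

The compounds shown leave open what other groups at this place, such as ethyl, methoxy or an amine, would do on either core. They also leave open whether the ester and the trimethoxy-substituted aniline ring are needed for this effect of the methyl.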